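Swapping the pyridine attachment on an alkyne-linked core

A few compounds are considered here, and "the series" means these few. Any claim that something is new, unique, unknown or untested is made for them only; others in the source may bear on it.

Of the compounds shown here, two have been measured in an assay on HEK293 cells for displacement of a labelled ligand from metabotropic glutamate receptor 5 (Homo sapiens), with a stated time of 2 h; on this read-out lower numbers stand for stronger inhibition and higher numbers for weaker inhibition. Compound 1, `CN1CCc2nc(C#Cc3cccnc3)ccc2C1=O`, gives 27400 nM. Compound 2, `O=C1c2ccc(C#Cc3ccccn3)nc2CCN1C1CCCCC1`, gives 2240 nM, the lowest of the two numbers, and the gap to compound 1 lies beyond the usual scatter. Compound 3, `O=C1c2ccc(C#Cc3cccnc3)nc2CCN1C1CCCCC1`, is yet to be measured; it differs from compound 2 by pyridin-3-yl in place of pyridin-2-yl on a triple-bonded carbon. Compound 1 carries the same pyridin-3-yl group, though it differs elsewhere too, and its weaker number gives only a loose hint. For compound 3 a step to a weaker number is expected, a 4.5-fold higher number from compound 2 to compound 3 (0.65 log units; beyond the scatter), giving an estimated 10000 nM with a range from 3000 nM to 30000 nM.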

Compound 3, inhibition constant: 15600 nM
Compound 3: middle estimate off by 1.6-fold (0.19 log units), on the low side, within the range that was stated.
By their numbers in this assay, from the lowest: compound 2; then compounds 3 and 1 (each within the scatter of the next).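

In this assay, with the rest of the structure unchanged, pyridin-3-yl in place of pyridin-2-yl on a triple-bonded carbon gives a 7.0-fold higher number from compound 2 to compound 3 (0.84 log units; beyond the scatter), so these two pyridine attachments are not interchangeable here. With pyridin-3-yl held in place, cyclohexyl in place of methyl on an amide-type nitrogen in a ring gives a 1.8-fold lower number from compound 1 to compound 3 (0.24 log units; within the scatter), leaving that pair indistinguishable. No measurement shown explains the gap between the two attachments.

Still open, as far as these compounds go, is how pyridin-4-yl or a plain phenyl ring would compare on the triple-bonded carbon. Also open, from the compounds shown here alone, is whether methyl in place of cyclohexyl would matter with pyridin-2-yl present.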